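The source may report more compounds than this note shows. Statements on the series, on what has been measured and on what is new or still open speak of the compounds shown alone.

Going by the values given here, compound 3 `O=C(COc1ccc2cc(/C=C3/SC(=O)NC3=O)ccc2c1)Nc1ccc([N+](=O)[O-])cc1` gives 4000 nM in an assay on isolated protein for inhibition of histone deacetylase 8 (Homo sapiens), with a stated time of 1 h (on this read-out higher numbers stand for weaker inhibition and lower numbers for stronger inhibition), one of only two numbers available, and the other, compound 2 `Cc1cc(Br)ccc1NC(=O)COc1ccc2cc(/C=C3/SC(=O)NC3=O)ccc2c1` at 7400 nM, sits within the usual scatter of it. Compound 1 `O=C(COc1ccc2cc(/C=C3/SC(=O)NC3=O)ccc2c1)Nc1ccccn1` reaches only the assay limit, > 50000 nM. Compound 4 `O=C(COc1ccc2cc(/C=C3/SC(=O)NC3=O)ccc2c1)Nc1ccc(F)cc1` differs from compound 3 by fluoro in place of nitro on an aromatic carbon. The step that bears most directly on this, a 1.9-fold lower number from compound 2 to compound 3 (0.27 log units; within the scatter), exchanged substituents on the group attached to the amide nitrogen and stayed within the scatter; the larger steps, an at least 6.7-fold lower number from compound 1 to compound 2 (0.82 log units; beyond the scatter) and an at least 12-fold lower number from compound 1 to compound 3 (1.09 log units; beyond the scatter), replaced the whole pyridin-2-yl ring and speak to a different kind of change. A small step is therefore expected, a 1.5-fold higher number from compound 3 to compound 4 (0.18 log units; within the scatter). Compound 4 is estimated at 6000 nM, within a range from 2500 nM to 15000 nM.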

Compound 4, half-maximal inhibitory concentration: 6600 nM
Beside the measured number, compound 4's estimate is 1.1-fold (0.04 log units) below it; the measured number falls inside the stated range.
By their numbers in this assay, from the lowest: compounds 3, 4 and 2 (each within the scatter of the next). At a limit, above all of these: compound 1.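

Replacing nitro with fluoro, para to a large group, gives a 1.7-fold higher number from compound 3 to compound 4 (0.22 log units; within the scatter), so at this position a single fluorine cannot be told apart from the larger nitro group. Changing the whole aryl group gives a 1.1-fold lower number from compound 2 to compound 4 (0.05 log units; within the scatter), which also leaves 4-fluorophenyl and 4-bromo-2-methylphenyl indistinguishable. Against pyridin-2-yl the result is an at least 7.5-fold lower number from compound 1 to compound 4 (0.87 log units; beyond the scatter), but this step starts from a limit for compound 1, not a number: the limit of > 50000 nM in this assay, at which 1 of the 4 values shown sits.

Going by these compounds, whether an amine or a carboxylic acid at this position would shift the number stays open. So does whether a plain unsubstituted phenyl ring would match these compounds.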